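Chloro for Bromo on Two Related Cores

This account rests on a few compounds, and the source may have more. Where it says the series, first, only, none or still open, it means among the compounds named here.

Compound 1, `COc1ccc(C2=NN(C3=NC(=O)/C(=C4\C(=O)Nc5ccc(Br)cc54)S3)C(c3ccc(OC)cc3)C2)cc1`, gives 210 nM.
Compound 2, `COc1ccc(C2=NN(C3=NC(=O)/C(=C4\C(=O)Nc5ccc(Cl)cc54)S3)C(c3ccc(OC)cc3)C2)cc1`, gives 220 nM.
Compound 3, `COc1ccc(-c2cc(-c3ccc(Cl)cc3)n(C3C(=O)Nc4ccc(Br)cc43)n2)cc1`, gives 8100 nM.

All three were measured in a functional assay on cells (Cancer cell lines, Homo sapiens) for cytotoxicity, read by sulforhodamine B assay, with a stated time of 48 h; on this read-out lower numbers stand for stronger inhibition of growth and higher numbers for weaker inhibition of growth. Compound 1 and compound 2 share one core, while compound 3 is built on another; the difference between the two cores is not broken down here. Compound 3 gives the highest number of the three, beyond the scatter from both others. From compound 1 to compound 2 the change is chloro in place of bromo on an aromatic carbon, and it made a 1.0-fold higher number from compound 1 to compound 2 (0.02 log units; within the scatter).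

Compound 4, `COc1ccc(-c2cc(-c3ccc(Cl)cc3)n(C3C(=O)Nc4ccc(Cl)cc43)n2)cc1`, is not yet measured. It arises from compound 3 by chloro in place of bromo on an aromatic carbon, which is the same change at the same place. The step from compound 3 to compound 4 is expected to be no change at the digits printed from compound 3 to compound 4 (within the scatter) because the earlier one was a 1.0-fold higher number from compound 1 to compound 2 (0.02 log units; within the scatter) on the other core. Compound 4 is thus estimated at 8100 nM, with an expected range from 4000 nM to 16000 nM.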

Compound 4, concentration for 50% growth inhibition: 6290 nM
Beside the measured number, compound 4's estimate is 1.3-fold (0.11 log units) above it, within the range that was stated.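

In this assay, chloro in place of bromo on an aromatic carbon gave a 1.3-fold lower number from compound 3 to compound 4 (0.11 log units; within the scatter). Set beside the same change on the core of compound 1, the two steps agree, so this change carried from one core to the other: the same change on two cores in this assay, a 1.0-fold higher number (0.02 log units; within the scatter) from compound 1 to compound 2 and a 1.3-fold lower number (0.11 log units; within the scatter) from compound 3 to compound 4, 1.3-fold (0.13 log units) apart, within the scatter of two such steps This shows only that exchanging these two halogens at this place left the number within the scatter on both cores; it does not show that any other change, or this one on a further core, would carry over in the same way.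

The compounds shown leave open what an amine or a carboxylic acid at this place would do. They also leave open whether either group would move the number equally on both cores.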